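This account rests on a few compounds, and the source may have more. Where it says the series, first, only, none or still open, it means among the compounds named here.

In an ADME assay on Caco-2 cells (Homo sapiens) for permeability (on this read-out higher numbers stand for higher permeability and lower numbers for lower permeability), compound 1 `COC(=O)N[C@H](C(=O)NN(CCC[C@@]1(O)Cc2ccc(cc2)/C=C\CNC(=O)[C@H](C(C)(C)C)NC1=O)Cc1ccc(Br)cc1)C(C)(C)C` gives 31 10^-6 cm/s and compound 2 `COC(=O)N[C@H](C(=O)NN(CCC[C@@]1(O)Cc2ccc(cc2)C/C=C\CNC(=O)[C@H](C(C)C)NC1=O)Cc1ccc(Br)cc1)C(C)(C)C` gives 9 10^-6 cm/s. Compound 2 is therefore the lower of the two numbers, by a gap beyond the usual scatter. Compound 3 `COC(=O)N[C@H](C(=O)NN(CCC[C@@]1(O)Cc2ccc(cc2)C/C=C\CNC(=O)[C@H](C(C)(C)C)NC1=O)Cc1ccc(Br)cc1)C(C)(C)C` departs from compound 2 through methyl in place of hydrogen on a saturated chain carbon bound to two saturated chain carbons and a saturated ring carbon. For the measured compounds named here, no measured step isolates this change. Going by the values given here, compound 1, at 31 10^-6 cm/s, offers the only higher number for comparison. In this assay a modest upward step is expected, a 1.8-fold higher number from compound 2 to compound 3 (0.25 log units; within the scatter), not clearly beyond the scatter. For compound 3 the estimated value is 16 10^-6 cm/s, with an expected range of 7 10^-6 cm/s to 35 10^-6 cm/s.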

Compound 3, apparent permeability: 10 10^-6 cm/s
Compound 3: the middle estimate sits 1.6-fold (0.20 log units) above what was measured, within the range that was stated.
By their numbers in this assay, from the lowest: compounds 2 and 3 (each within the scatter of the next); then compound 1.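

In this assay, the change from isopropyl to tert-butyl on a saturated chain carbon bound to two saturated chain carbons and a saturated ring carbon gives a 1.1-fold higher number from compound 2 to compound 3 (0.05 log units; within the scatter) and so stays within the scatter. For the compounds shown here, this is the first measured step that isolates methyl in place of hydrogen at this position. No evidence is available that bears on this result. On these data alone, whether an amine, a carboxylic acid or a longer chain at this position would give a number beyond the scatter remains open.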